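The compounds below may be only part of what the source reports. "The series", "measured", "known", "first", "only" and "open" are said of these compounds alone.

Compound 1 `CC(C)COC(=O)Nc1ccc([Se][Se]c2ccc(NC(=O)OCC(C)C)cc2)cc1`: 48600 nM
Compound 2 `C=CCOC(=O)Nc1ccc([Se]C#N)cc1`: 48600 nM
Compound 3 `N#C[Se]c1ccc(NC(=O)Oc2ccccc2)cc1`: 41700 nM

In a functional assay on HT-29 cells (Homo sapiens) for cytotoxicity, read by MTT assay, with a stated time of 72 h (a lower number here means a stronger inhibitor of growth, a higher number a weaker inhibitor of growth), compound 2 stands level with compound 1 at the digits shown, the two together being the highest of the three numbers, and compound 3 lies furthest from it. Compound 4 `N#C[Se]c1ccc(NC(=O)OCc2ccccc2)cc1` differs from compound 2 in one place: phenyl in place of vinyl on a saturated chain carbon bound to an oxygen next to a carbonyl group. Among the measured compounds shown here, the one measured step that bears on this change is the related exchange of the group on that oxygen, which gave a 1.2-fold lower number from compound 2 to compound 3 (0.07 log units; within the scatter). On that basis no step beyond the scatter is expected here; the estimated step is a 1.1-fold lower number from compound 2 to compound 4 (0.03 log units; within the scatter). Compound 4 is therefore expected to give about 45000 nM, within a range from 20000 nM to 100000 nM.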

Compound 4, concentration for total growth inhibition: 41200 nM
Beside the measured number, compound 4's estimate is 1.1-fold (0.04 log units) above it; measured number inside the range.
By their numbers in this assay, from the lowest: compounds 4, 3, 1 and 2 (each within the scatter of the next).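

In this assay, phenyl in place of vinyl on a saturated chain carbon bound to an oxygen next to a carbonyl group gives a 1.2-fold lower number from compound 2 to compound 4 (0.07 log units; within the scatter). So a six-membered aromatic ring can stand on this chain carbon with no step beyond the scatter, which the earlier step, with phenyl directly on the oxygen, did not show. Nothing measured here offers an explanation for this result. Still open, going by these compounds, is whether an amine or a carboxylic acid on this chain carbon would give a step beyond the scatter. The same question holds for a longer chain ending in phenyl.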